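Urea nitrogen carrying benzyl instead of phenyl

The source may hold more compounds than are shown below. What is called first, only, known or untested is meant among the compounds shown, and "the series" means these compounds.

Of the compounds shown here, three have been measured in an assay on CHO cells for displacement of a labelled ligand from histamine receptor H3 (Macaca mulatta), read by scintillation counting, with a stated time of 1 h (a lower number here means a stronger inhibitor, a higher number a weaker inhibitor), and their numbers sit close together. Compound 1 `Cc1c(Cl)cc(NC(=O)Nc2ccc(OCCCN3CCCCC3)cc2)cc1Cl` gives 18.2 nM, compound 3 `CC(=O)N1CCN(C(=O)Nc2ccc(N3CCC(N4CCCC4C)C3)c(C)c2)CC1` gives 23 nM, and compound 2 `CC1CCCN1C1CCN(c2ccc(NC(=O)Nc3cc(Cl)cc(Cl)c3)cc2)C1` gives 19.1 nM. Compound 2 stands second highest of the three, and its gaps to both compound 1 and compound 3 lie within the usual scatter, so no order among them can be claimed. Compound 4 `CC1CCCN1C1CCN(c2ccc(NC(=O)NCc3cc(Cl)cc(Cl)c3)cc2)C1` has not been measured. It differs from compound 2 in one place: 3,5-dichlorobenzyl in place of 3,5-dichlorophenyl on an amide-type nitrogen. Among the measured compounds shown here, no measured pair shows this change, so its effect cannot be read from the data. A modest weakening is expected, with a result inside the scatter also plausible. Compound 4 is estimated at 40 nM, with a range from 10 nM to 160 nM. That estimate corresponds to an expected step of a 2.1-fold higher number from compound 2 to compound 4 (0.32 log units; beyond the scatter).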

Compound 4, inhibition constant: 7.1 nM
For compound 4 the middle estimate is 5.6-fold (0.75 log units) above the measured one, and the stated range ends above it.
By their numbers in this assay, from the lowest: compound 4; then compounds 1, 2 and 3 (each within the scatter of the next).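

In this assay, 3,5-dichlorobenzyl in place of 3,5-dichlorophenyl on an amide-type nitrogen gives a 2.7-fold lower number from compound 2 to compound 4 (0.43 log units; beyond the scatter). Among the compounds shown here, this is the first single-place comparison, and it shows that the number at this position does respond to a change, with one extra carbon making the inhibitor stronger rather than weaker. No measured information on why this happens is available here.

From the compounds shown here alone, whether a longer chain, such as 2-(3,5-dichlorophenyl)ethyl, would continue this trend remains open. So does the role of the two chlorines, which a plain benzyl group would test.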